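Aryl phosphate variation on a shared-core series

The source may report more compounds than this note shows. Statements on the series, on what has been measured and on what is new or still open speak of the compounds shown alone.

Measured in a functional assay on T98G cells (Homo sapiens) for cytotoxicity, read by MTT assay, with a stated time of 48 h; a higher number here means a weaker inhibitor, a lower number a stronger inhibitor:
compound 1 `O=C(O[C@H]1C[C@H](n2cc(F)c(=O)[nH]c2=O)O[C@@H]1COP(=O)(O)Oc1ccccc1)c1ccccc1`: 810 nM
compound 2 `O=C(O[C@H]1C[C@H](n2cc(F)c(=O)[nH]c2=O)O[C@@H]1COP(=O)(O)Oc1cccnc1)c1ccccc1`: 1300 nM
compound 3 `O=C(O[C@H]1C[C@H](n2cc(F)c(=O)[nH]c2=O)O[C@@H]1COP(=O)(O)Oc1ccc2ncccc2c1)c1ccccc1`: 1300 nM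

Compound 2 stands level with compound 3 at the digits given, the two together the highest of the three numbers. Its nearest neighbour is compound 3, no change at the digits printed from compound 2 to compound 3 (within the scatter); its furthest is compound 1, a 1.6-fold higher number from compound 1 to compound 2 (0.21 log units; within the scatter). The third step, a 1.6-fold higher number from compound 1 to compound 3 (0.21 log units; within the scatter), is likewise within the scatter.

Compound 4 `C[n+]1cccc(OP(=O)([O-])OC[C@H]2O[C@@H](n3cc(F)c(=O)[nH]c3=O)C[C@@H]2OC(=O)c2ccccc2)c1` differs from compound 2 in this way: a group of 11 heavy atoms (6 carbon, 1 nitrogen, 3 oxygen, 1 phosphorus; one six-membered aromatic ring with 1 hetero atom) in place of a group of 10 heavy atoms (5 carbon, 1 nitrogen, 3 oxygen, 1 phosphorus; one six-membered aromatic ring with 1 hetero atom), on an oxygen on a saturated carbon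

Going by the values given here, no measured step makes this kind of change. The three steps that exist each swap the aromatic group on the phosphate oxygen, and all lie within the scatter, so for compound 4 no step beyond the scatter is expected in this assay. Compound 4 is estimated at 1300 nM, with a range from 500 nM to 3500 nM. The expected step is no change at the digits printed from compound 2 to compound 4 (within the scatter).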

Compound 4, half-maximal inhibitory concentration: 3480 nM
The estimate for compound 4 lay 2.7-fold (0.43 log units) below the measured number; low and high end bracket the measured number.
By their numbers in this assay, from the lowest: compounds 1, 2 and 3 (each within the scatter of the next); then compound 4.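

In this assay, the aromatic swaps on the phosphate oxygen stayed within the scatter, whereas the group of 11 heavy atoms in compound 4, with 0 hydrogen-bond donors against 1, gives a 2.7-fold higher number from compound 2 to compound 4 (0.43 log units; beyond the scatter) as a modest step beyond it. The same group gives a 4.3-fold higher number from compound 1 to compound 4 (0.63 log units; beyond the scatter) as a modest step against the phenyl group too, so this position does respond to some changes. No supporting data explain the shift.

From the compounds shown here alone, whether an amine or a carboxylic acid on the phenyl group would shift the number similarly remains open. Also open, going by these compounds, is whether a longer chain in place of the added carbon would do so.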